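Swapping the 3-chlorophenyl for an (ethoxycarbonyl)methyl group

The source may report more compounds than this note shows. Statements on the series, on what has been measured and on what is new or still open speak of the compounds shown alone.

Of the compounds shown here, two have been measured so far. Compound 1 `COc1cc(C2Oc3cc([C@H]4Oc5cc(O)cc(O)c5C(=O)[C@@H]4O)ccc3OC2COC(=O)c2ccccc2)ccc1O` gives 12700 nM in a functional assay on liver (Rattus norvegicus, strain Sprague-Dawley) for inhibition, with a stated time of 1 h; on this read-out higher numbers stand for weaker inhibition and lower numbers for stronger inhibition. Compound 2 `COc1cc(C2Oc3cc([C@H]4Oc5cc(O)cc(O)c5C(=O)[C@@H]4O)ccc3OC2COC(=O)c2cccc(Cl)c2)ccc1O` gives 14200 nM in this assay. The one step between them, a 1.1-fold higher number from compound 1 to compound 2 (0.05 log units; within the scatter), stays within the scatter, so on the numbers shown compound 2 stands level with compound 1 and neither can be called the stronger inhibitor.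

Compound 3 `CCOC(=O)CC(=O)OCC1Oc2ccc([C@H]3Oc4cc(O)cc(O)c4C(=O)[C@@H]3O)cc2OC1c1ccc(O)c(OC)c1` has not yet been measured in this assay. It differs from compound 2 in a single place: (ethoxycarbonyl)methyl in place of 3-chlorophenyl on a carbonyl carbon. Going by the values given here, the only measured step, a 1.1-fold higher number from compound 1 to compound 2 (0.05 log units; within the scatter), concerned a chloro in place of hydrogen on an aromatic carbon and produced no change beyond the scatter; it says nothing about removing that aromatic ring altogether, so it bears on the new step only loosely. Among the compounds with values here, with no closer precedent, no shift beyond the scatter is expected, the estimated step being a 1.0-fold lower number from compound 2 to compound 3 (0.01 log units; within the scatter). Compound 3 is therefore expected to give about 14000 nM in this assay, with a likely range from 5000 nM to 40000 nM.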

Compound 3, half-maximal inhibitory concentration: 33400 nM
The estimate for compound 3 lay 2.4-fold (0.38 log units) below the measured number; the measured number falls inside the stated range.
By their numbers in this assay, from the lowest: compounds 1 and 2 (each within the scatter of the next); then compound 3.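

In this assay, (ethoxycarbonyl)methyl in place of 3-chlorophenyl on the carbonyl carbon gives a 2.4-fold higher number from compound 2 to compound 3 (0.37 log units; beyond the scatter), and the same group in place of phenyl gives a 2.6-fold higher number from compound 1 to compound 3 (0.42 log units; beyond the scatter). Both steps lie beyond the scatter, so this position, where adding a chloro to the aromatic ring had produced no change beyond the scatter, does respond when the ring itself is replaced, with modestly weaker inhibition. No information is given here that would account for this loss of inhibition.

The change removes an aromatic ring and brings in an open chain with an ester at the same time, so the compounds shown cannot separate the loss of the ring from the arrival of the chain and its hydrogen-bond acceptors. Going by these compounds, it remains open whether a cyclohexyl group on the same carbonyl carbon, which would keep a ring without aromaticity, would stand level with the aromatic compounds, and whether a carboxylic acid in place of the ethyl ester would shift the number further.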